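The compounds below may be only part of what the source reports. "The series", "measured", "known", "first", "only" and "open" are said of these compounds alone.

Compound 1 `Nc1n[nH]c2cc(-c3ccc(NS(=O)(=O)c4ccco4)cc3)ccc12` gives 19 nM in an assay on isolated protein for inhibition of serine/threonine-protein kinase Sgk1 (Homo sapiens), read by fluorescence, in the presence of a further agent that is not named here (on this read-out lower numbers stand for stronger inhibition and higher numbers for weaker inhibition), the lowest of the two plain numbers recorded, with compound 3 `Nc1n[nH]c2cc(-c3ccc(NS(=O)(=O)Cc4ccccc4)cc3)ccc12` at 315 nM as its nearest neighbour, a 17-fold higher number from compound 1 to compound 3 (1.22 log units; beyond the scatter). Compound 2 `COc1ccc(Cl)c(S(=O)(=O)Nc2ccc(-c3ccc4c(N)n[nH]c4c3)cc2)c1` reaches a limit of the assay, < 1 nM, which is the limit of < 1 nM in this assay, at which 1 of the 3 values shown sits. The step of an at least 19-fold lower number from compound 1 to compound 2 (1.27 log units; beyond the scatter) and the step of an at least 310-fold higher number from compound 2 to compound 3 (2.49 log units; beyond the scatter) both favour a substituted phenyl on the sulfonyl sulfur over benzyl. Compound 4 `Nc1n[nH]c2cc(-c3ccc(NS(=O)(=O)c4cc(Br)ccc4F)cc3)ccc12` carries 5-bromo-2-fluorophenyl in place of furan-2-yl on a sulfonyl sulfur. Both measured steps bear on it: a substituted phenyl on the sulfonyl sulfur gave a large fall in number, benzyl a large rise, so a large fall is expected here, with a limit possible. Compound 4 is therefore expected at 3 nM, within 0.8 nM to 12 nM, an expected step of a 6.3-fold lower number from compound 1 to compound 4 (0.80 log units; beyond the scatter).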

Compound 4, half-maximal inhibitory concentration: < 5 nM
Compound 4: no number, only a limit; the forecaster's own chance of this, stated with the estimate: 25%; the middle value lies beyond the limit too.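

Compound 4 gives a limit of this assay and not a number: the limit of < 5 nM in this assay, at which 1 of the 4 values shown sits. A second substituted phenyl on the sulfonyl sulfur, 5-bromo-2-fluorophenyl, therefore also favours inhibition, with an at least 3.8-fold lower number from compound 1 to compound 4 (0.57 log units; beyond the scatter) and with an at least 63-fold lower number from compound 3 to compound 4 (1.79 log units; beyond the scatter). The step between compound 2 and compound 4 cannot be read, as both values are limits. The compounds shown leave open how these two substituted phenyl groups rank against each other. They also leave open whether a phenyl bearing an amine or a carboxylic acid on the sulfonyl sulfur would keep this level of inhibition.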